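Three-carbon amide chain on a boron-containing core: aryl replacement

The source may report more compounds than this note shows. Statements on the series, on what has been measured and on what is new or still open speak of the compounds shown alone.

This account follows a small set of amides built on a shared core, measured in a functional assay on HCT-116 cells (Homo sapiens) for antiproliferative activity, read by MTT assay, with a stated time of 72 h; a lower number here means a stronger inhibitor, a higher number a weaker inhibitor. Compound 1 `CCNC(=O)CCc1cccc2c1B(O)OC2` carries an ethyl on the amide nitrogen and reports only a limit, > 100000 nM (the limit of > 100000 nM in this assay, at which 1 of the 3 values shown sits). Compound 2 `Cc1ccc(NC(=O)CCc2cccc3c2B(O)OC3)cc1` gives 4500 nM. Compound 3 `O=C(CCc1cccc2c1B(O)OC2)Nc1cccc(I)c1` gives 2300 nM, and the step of a 2.0-fold lower number from compound 2 to compound 3 (0.29 log units; within the scatter) means compound 2 and compound 3 cannot be told apart. The two large steps are an at least 22-fold lower number from compound 1 to compound 2 (1.34 log units; beyond the scatter) and an at least 43-fold lower number from compound 1 to compound 3 (1.63 log units; beyond the scatter), both arising when an aryl group replaces the ethyl.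

Compound 4 `COc1cc(OC)cc(-c2cccc(NC(=O)CCc3cccc4c3B(O)OC4)c2)c1` is not yet measured. It differs from compound 3 by 3,5-dimethoxyphenyl in place of iodo on an aromatic carbon. Going by the values given here, no measured step shows what a second aromatic ring on the amide aryl does; the only aryl-to-aryl comparison, a 2.0-fold lower number from compound 2 to compound 3 (0.29 log units; within the scatter), is within the scatter. Compound 4 is therefore expected to stay close to compound 3, with a step of a 1.5-fold lower number from compound 3 to compound 4 (0.19 log units; within the scatter). The estimate for compound 4 is 1500 nM, within 400 nM to 6000 nM.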

Compound 4, half-maximal inhibitory concentration: 53 nM
Compound 4: the middle estimate sits 28-fold (1.45 log units) above what was measured; measured number below the stated range.
By their numbers in this assay, from the lowest: compound 4; then compounds 3 and 2 (each within the scatter of the next). At a limit, above all of these: compound 1.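

In this assay the aromatic carbon that carries iodo in compound 3 proves to be a place where a change can move the number strongly: 3,5-dimethoxyphenyl in place of iodo gives a 43-fold lower number from compound 3 to compound 4 (1.64 log units; beyond the scatter) and so adds a second aromatic ring to the amide aryl. The earlier aryl comparison showed nothing of this size, since a 2.0-fold lower number from compound 2 to compound 3 (0.29 log units; within the scatter) and so leaves those two compounds indistinguishable. Nothing measured on these compounds accounts for the size of the new step.

The compounds shown leave open whether the gain belongs to the added ring itself or to its two methoxy groups, which a plain phenyl or a single methoxy group could separate. On these data alone, how a pyridine ring at this carbon, or a longer chain linking the amide to the shared core, would read also remains open.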